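Replacing the Cyclopentylamino Group of Compound 3

The compounds below may be only part of what the source reports. "The series", "measured", "known", "first", "only" and "open" are said of these compounds alone.

Measured compounds:
compound 1, `CCOC(=O)Nc1sc(-c2ccc(Cl)cc2)c(-c2ccc(Cl)cc2)c1C(=O)NC1CC1`, gives 27600 nM in a functional assay on PC-3 cells (Homo sapiens) for inhibition, read by sulforhodamine B assay, with a stated time of 72 h; on this read-out lower numbers stand for stronger inhibition and higher numbers for weaker inhibition;
compound 2, `Nc1sc(-c2ccc(Cl)cc2)c(-c2ccc(Cl)cc2)c1C(=O)NCc1ccccc1`, gives 31800 nM in this assay;
compound 3, `Nc1sc(-c2ccc(Cl)cc2)c(-c2ccc(Cl)cc2)c1C(=O)NC1CCCC1`, gives 21200 nM in this assay.

Compound 3 has the lowest of the three numbers, yet its gap to compound 1 and its gap to compound 2 are both within the scatter, so the three compounds sit together and none can be called stronger than another. Going by the values given here, the only measured step that touches the amide, a 1.5-fold lower number from compound 2 to compound 3 (0.18 log units; within the scatter), lies within the scatter: putting cyclopentyl in place of benzyl on an amide-type nitrogen left the number where it was.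

Compound 4, `CC1CN(C(=O)c2c(N)sc(-c3ccc(Cl)cc3)c2-c2ccc(Cl)cc2)CCN1`, differs from compound 3 in one place: 3-methylpiperazin-1-yl in place of cyclopentylamino on a carbonyl carbon. This exchanges the whole cyclopentylamino group on the carbonyl carbon, a larger change than the swap between compound 2 and compound 3. Among the compounds with values here, no measured pair shows such a change, and the single step that exists suggests the group on this side of the carbonyl has little hold over the number. The expected step is therefore none beyond the scatter, a 1.1-fold higher number from compound 3 to compound 4 (0.05 log units; within the scatter). Within the data shown here, compound 4 is estimated at 24000 nM, with a wide range from 8000 nM to 70000 nM; the width reflects that no measured step covers this kind of change.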

Compound 4, half-maximal inhibitory concentration: 7210 nM
For compound 4 the middle estimate is 3.3-fold (0.52 log units) above the measured one; the measured number lies below the stated range.
By their numbers in this assay, from the lowest: compound 4; then compounds 3, 1 and 2 (each within the scatter of the next).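

In this assay, the group on the carbonyl carbon turns out to matter: 3-methylpiperazin-1-yl in place of cyclopentylamino gives a 2.9-fold lower number from compound 3 to compound 4 (0.47 log units; beyond the scatter), and in place of benzylamino it gives a 4.4-fold lower number from compound 2 to compound 4 (0.64 log units; beyond the scatter), whereas the earlier swap of benzyl for cyclopentyl stayed within the scatter. The exchange with cyclopentylamino alters several features at once, replacing a five-membered ring of carbon only with a six-membered ring holding 2 hetero atoms, and raising the count of hydrogen-bond acceptors from 0 to 1, so these compounds cannot show which feature goes with the lower number. No measurement available here accounts for the step.

The compounds shown leave open whether the methyl group or the second nitrogen goes with the lower number; a plain piperazin-1-yl group would test the first, and a morpholin-4-yl group, with an oxygen in place of that nitrogen, would test the second. An open-chain amine such as diethylamino on the carbonyl carbon would also show whether a similar number can be reached without a ring.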